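The source may hold more compounds than are shown below. What is called first, only, known or untested is meant among the compounds shown, and "the series" means these compounds.

Read in a functional assay on the whole organism for agonist activity, with Mus musculus as the target (on this read-out lower numbers stand for an effect already at smaller amounts and higher numbers for an effect only at larger amounts of compound), the compounds stand as follows
- compound 1 `CC(=O)N(C)C(C)C#CCn1ccnc1` gives 2 mg/kg
- compound 2 `CC(=O)N(C)CC#CCn1ccnc1` gives 0.97 mg/kg
- compound 3 `CCOC(=O)N(C)C(C)C#CCn1ccnc1` is still unmeasured

Compound 1 has the higher number of the two measured compounds. Compound 3 differs from compound 1 by ethoxy in place of methyl on a carbonyl carbon and in words this is ethoxy in place of methyl on a carbonyl carbon, so that acetyl becomes ethoxycarbonyl. Among the measured compounds shown here, no measured step touches that carbonyl carbon. For the measured compounds named here, the only measured step is a 2.1-fold lower number from compound 1 to compound 2 (0.31 log units; beyond the scatter) and it is modest, at another place in the molecule, so it offers only a rough guide to size. In that step a methyl left and the number fell, which gives weak grounds for expecting the number to rise when heavy atoms enter here. The data cannot settle the direction, so a step of modest to moderate size toward a higher number is expected, with a wide margin. Compound 3 is estimated at 4 mg/kg with an expected range of 1 mg/kg to 16 mg/kg in this assay as the likely outcome. This estimate amounts to an expected 2.0-fold higher number from compound 1 to compound 3 (0.30 log units; within the scatter) when the measurement arrives.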

Compound 3, dose for half-maximal effect: > 100 mg/kg
Compound 3: a limit, no number (the forecaster's own chance of this, stated with the estimate: 15%); middle value at least 25-fold (1.39 log units) from the limit.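

Among the compounds shown here, until compound 3, no measured step touched the carbonyl carbon whose other neighbour is the amide-type nitrogen. With ethoxy in place of methyl on that carbon, compound 3 gives > 100 mg/kg in this assay, which is a limit of the assay and not a number: the limit of > 100 mg/kg in this assay, at which 1 of the 3 values shown sits.
The change from acetyl to ethoxycarbonyl reads as an at least 50-fold higher number from compound 1 to compound 3 (1.69 log units; beyond the scatter), a far larger step than the one on the saturated chain carbon, a 2.1-fold lower number from compound 1 to compound 2 (0.31 log units; beyond the scatter). Among the compounds shown, this makes the carbonyl carbon the more sensitive of the two places changed, with acetyl going with a measured dose and ethoxycarbonyl giving only a limit.

Whether the step belongs to the oxygen of the ethoxy or to its two carbons stays open, as neither a propionyl nor a methoxycarbonyl group on that carbonyl carbon is among the compounds shown. Also open, as far as these compounds go, is whether ethoxycarbonyl would give the same outcome on the core of compound 2, and how far the true dose of compound 3 lies beyond the limit.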